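The compounds below may be only part of what the source reports. "The series", "measured", "known", "first", "only" and "open" are said of these compounds alone.

Three close relatives of one scaffold have been tested in a functional assay on LoVo cells (Homo sapiens) for inhibition, read by MTT assay, with a stated time of 72 h (on this read-out higher numbers stand for weaker inhibition and lower numbers for stronger inhibition), and a fourth awaits its result. Compound 1 `Cc1noc(C)c1-c1cnc(N)c(Oc2ccc(C(=O)Nc3cc(Cl)ccn3)cc2)n1` is the starting point. In this assay compound 1 gives only a limit, > 100000 nM, not a number (the limit of > 100000 nM in this assay, at which 1 of the 3 values shown sits).

Compound 2 `Cc1noc(C)c1-c1cnc(N)c(Oc2ccc(C(=O)Nc3ncccc3Cl)cc2)n1` keeps everything of compound 1 except the chloropyridine on the amide: 3-chloropyridin-2-yl in place of 4-chloropyridin-2-yl on an amide-type nitrogen. In this assay compound 2 gives 14800 nM, which makes the step of an at least 6.7-fold lower number from compound 1 to compound 2 (0.82 log units; beyond the scatter).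

Compound 3 `Cn1cc(-c2cnc(N)c(Oc3ccc(C(=O)Nc4cc(Cl)ccn4)cc3)n2)cn1` instead keeps the chloropyridine of compound 1 and changes the small ring on the shared core: 1-methyl-1H-pyrazol-4-yl in place of 3,5-dimethyl-1,2-oxazol-4-yl on an aromatic carbon. In this assay compound 3 gives 26600 nM, so the step is an at least 3.7-fold lower number from compound 1 to compound 3 (0.57 log units; beyond the scatter). The values of compound 2 and compound 3 lie within the scatter of each other.

Compound 4 `Cn1cc(-c2cnc(N)c(Oc3ccc(C(=O)Nc4ncccc4Cl)cc3)n2)cn1` has not yet been measured. It differs from compound 3 by 3-chloropyridin-2-yl in place of 4-chloropyridin-2-yl on an amide-type nitrogen, the same change, at the same place, that turns compound 1 into compound 2. For compound 4 the step from compound 3 is expected to be about a 6.7-fold lower number from compound 3 to compound 4 (0.82 log units; beyond the scatter), resting on the step of an at least 6.7-fold lower number from compound 1 to compound 2 (0.82 log units; beyond the scatter) seen for this change, while keeping in mind that this earlier step starts from a limit of > 100000 nM in this assay, at which 1 of the 3 values shown sits, and its true size is not fixed. Compound 4 is therefore estimated at 4000 nM, expected to fall between 1000 nM and 15000 nM.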

Compound 4, half-maximal inhibitory concentration: 16500 nM
Estimate against measurement, compound 4: 4.1-fold (0.62 log units) below, and the stated range ends below it.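

In this assay, putting 3-chloropyridin-2-yl in place of 4-chloropyridin-2-yl on the core of compound 3 gives a 1.6-fold lower number from compound 3 to compound 4 (0.21 log units; within the scatter), so the clear step seen on the core of compound 1 does not carry over at the same size, and the two steps differ: the same change on two cores in this assay, an at least 6.7-fold lower number (0.82 log units; beyond the scatter) from compound 1 to compound 2 and a 1.6-fold lower number (0.21 log units; within the scatter) from compound 3 to compound 4, at least 4.1-fold (0.62 log units) apart, beyond the scatter of two such steps. The swap of the small ring on the shared core, 1-methyl-1H-pyrazol-4-yl in place of 3,5-dimethyl-1,2-oxazol-4-yl, behaves likewise when the amide carries 3-chloropyridin-2-yl, giving a 1.1-fold higher number from compound 2 to compound 4 (0.05 log units; within the scatter), which again does not match its earlier step: the same change on two cores in this assay, an at least 3.7-fold lower number (0.57 log units; beyond the scatter) from compound 1 to compound 3 and a 1.1-fold higher number (0.05 log units; within the scatter) from compound 2 to compound 4, at least 4.1-fold (0.62 log units) apart, beyond the scatter of two such steps. What this does not show is the true size of either earlier step, or why the steps fail to transfer, since both start from compound 1, which gives only a limit and not a number: the limit of > 100000 nM in this assay, at which 1 of the 4 values shown sits.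

Only two placements of the chlorine and two small rings on the core appear here, so four compounds cannot say whether any other substitution would move the result beyond the scatter. Left open, for instance, is what a methyl or a methoxy group in place of the chlorine, or an amine or a carboxylic acid on the pyridine, would do on either core.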